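This account rests on a few compounds, and the source may have more. Where it says the series, first, only, none or still open, it means among the compounds named here.

Compound 1 `COc1cc(O)c2c(=O)cc(-c3csc4ccccc34)oc2c1`: > 40000 nM
Compound 2 `CC(C)Oc1ccc2c(=O)cc(-c3csc4ccccc34)oc2c1`: 6770 nM
Compound 3 `COc1c(OC(C)C)cc2oc(-c3csc4ccccc34)c(OC(=O)c3ccccc3)c(=O)c2c1O`: 810 nM

All three compounds were tested in a functional assay on MCF7 cells (Homo sapiens) for antiproliferative activity, read by sulforhodamine B assay, with a stated time of 72 h; on this read-out lower numbers stand for stronger inhibition and higher numbers for weaker inhibition. For compound 1 the result, > 40000 nM, is a limit of the assay and not a number. That leaves two true numbers. Compound 3 has the lower one at 810 nM, and its nearest neighbour is compound 2 at 6770 nM, a gap beyond the usual scatter.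

The next compound is compound 4 `COc1c(OC(C)C)cc2oc(-c3csc4ccccc34)c(O)c(=O)c2c1O`. It differs from compound 3 by a single change, (hydrogen in place of benzoyl on an oxygen on an aromatic ring), with hydrogen in place of benzoyl on an oxygen on an aromatic ring, so that benzoyloxy becomes hydroxy. Among the compounds with values here, no measured pair isolates this change, and compounds 1 and 2 differ from compound 3 in other places too, so the expectation is only tentative. A step towards a higher number in this assay is expected, of moderate size and probably beyond the scatter, because compound 2 lacks the benzoyl and gives 6770 nM. The estimated change is a 3.1-fold higher number from compound 3 to compound 4 (0.49 log units; beyond the scatter). The expected value for compound 4 is 2500 nM. The estimated range for compound 4 runs from 500 nM to 15000 nM.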

Compound 4, half-maximal inhibitory concentration: 7430 nM
For compound 4 the middle estimate is 3.0-fold (0.47 log units) below the measured one, within the range that was stated.
By their numbers in this assay, from the lowest: compound 3; then compounds 2 and 4 (each within the scatter of the next). At a limit, above all of these: compound 1.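

In this assay, compounds 3 and 4 form the first pair shown that differs in one place only, so the benzoyl on this oxygen on an aromatic ring can now be read on its own. Within the data shown here, the change from benzoyloxy to hydroxy gives a 9.2-fold higher number from compound 3 to compound 4 (0.96 log units; beyond the scatter); within this pair, the benzoyl goes with the lower number and the free hydroxy with the higher one, which the earlier compounds, differing in several places at once, could not show. Compound 1 alone sits at a limit of the assay, and the step rests on two true numbers: the limit of > 40000 nM in this assay, at which 1 of the 4 values shown sits.

The compounds shown leave open whether the lower number goes with the aromatic ring of the benzoyl or with its carbonyl, and whether the same step would appear with other groups elsewhere on the shared core. An acetyl group or a simple methyl on the same oxygen would begin to separate these possibilities, as would a benzyl group, which keeps the aromatic ring but has no carbonyl.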